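A few compounds are considered here, and "the series" means these few. Any claim that something is new, unique, unknown or untested is made for them only; others in the source may bear on it.

Working notes on the dinitrobenzoyl series in an assay on isolated protein (blood) for inhibition of Polyunsaturated fatty acid 5-lipoxygenase (Homo sapiens), read by ELISA, with stated times of 15 min and 30 min; a lower number here means a stronger inhibitor, a higher number a weaker inhibitor.

Of the compounds shown here, three carry numbers so far. Compound 1, `O=C(Oc1cccc(-c2ccccc2)c1)c1cc([N+](=O)[O-])cc([N+](=O)[O-])c1`, gives 38000 nM. Compound 3, `O=C(NCc1cccc(Br)c1)c1cc([N+](=O)[O-])cc([N+](=O)[O-])c1`, gives 14400 nM. Compound 2, `O=C(Nc1cccc(Cl)c1)c1cc([N+](=O)[O-])cc([N+](=O)[O-])c1`, reaches only the limit of the assay, > 50000 nM, so for compound 2 there is no number, only a boundary. Among the three, compound 2 stands at the limit of > 50000 nM in this assay, at which 1 of the 3 values shown sits, while compound 3 and compound 1 both sit inside the measurable range.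

The next compound in line is compound 4, `O=C(Nc1cccc(-c2ccccc2)c1)c1cc([N+](=O)[O-])cc([N+](=O)[O-])c1`. It differs from compound 2 in one place: phenyl in place of chloro on an aromatic carbon.

For the measured compounds named here, no step between two measured compounds is available to calibrate this change, so the expectation rests on the values shown alone. Since compound 2 sits at a limit, the step to compound 4 can only be expected to move in the direction of a measurable number or to stay at the limit; a move toward weaker inhibition cannot be seen from here. Compound 1 at 38000 nM suggests that a phenyl-bearing member of the series can be measured. The step from compound 2 to compound 4 is therefore expected as an at least 1.6-fold lower number from compound 2 to compound 4 (0.22 log units; that floor lies within the scatter), with a real chance that the assay again reports only a limit. Compound 4 is estimated at 30000 nM, within 10000 nM to 80000 nM.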

Compound 4, half-maximal inhibitory concentration: > 50000 nM
Compound 4 was reported as a limit (the forecaster's own chance of this, stated with the estimate: 35%); middle value at least 1.6-fold (0.22 log units) from the limit.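

In this assay compound 4 gives > 50000 nM as a limit, not a number. Compound 2 stands at the same limit, so no step can be read between compound 2 and compound 4: the limit of > 50000 nM in this assay, at which 2 of the 4 values shown sit. Left open is whether phenyl in place of chloro on an aromatic carbon changes inhibition at all.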